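Replacing the 3-carboxypyrrolidin-1-yl group of compound 2

The compounds below may be only part of what the source reports. "The series", "measured", "known", "first", "only" and "open" are said of these compounds alone.

Compound 1 `COc1ccc(/C=C\c2cc(OC)c(OC)c(OC)c2)cc1OCc1ccc(CN[C@H](C(=O)O)[C@H](C)O)cc1`: > 50000 nM, a limit
Compound 2 `COc1ccc(/C=C\c2cc(OC)c(OC)c(OC)c2)cc1OCc1ccc(CN2CC[C@@H](C(=O)O)C2)cc1`: 27000 nM
Compound 3 `COc1ccc(/C=C\c2cc(OC)c(OC)c(OC)c2)cc1OCc1ccc(CN[C@H](C(=O)O)[C@@H](C)O)cc1`: not yet measured

Among the compounds with values here, in an ADME assay on HEK293 cells (Homo sapiens) for cytotoxicity, read by CCK-8 assay, with a stated time of 48 h (a lower number here means a stronger inhibitor, a higher number a weaker inhibitor), compound 2 gives 27000 nM, the only actual number so far. Compound 1 gives > 50000 nM, which is a limit and not a number. The change to compound 3 is (1-carboxy-2-hydroxypropyl)amino in place of 3-carboxypyrrolidin-1-yl on a saturated chain carbon bound to an aromatic carbon. Within the data shown here, one measured step bears on it, the same exchange of groups run the other way: an at least 1.8-fold lower number from compound 1 to compound 2 (0.26 log units; that floor lies within the scatter). Read in reverse, that step from compound 1 suggests a higher number for compound 3, though only modestly so, and the evidence for any shift is thin. The expected change is a 1.8-fold higher number from compound 2 to compound 3 (0.25 log units; within the scatter). A reported limit rather than a number is also a real possibility for compound 3. For compound 3 the estimated value is 48000 nM, with an expected range of 22000 nM to 100000 nM.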

Compound 3, half-maximal inhibitory concentration: > 50000 nM
Compound 3 was reported as a limit; the forecaster's own chance of this, stated with the estimate: 50%; middle value at least 1.0-fold (0.01 log units) away from the limit.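

With compound 3, the (1-carboxy-2-hydroxypropyl)amino group on this saturated chain carbon bound to an aromatic carbon is reported as a limit in this assay in a second drawn configuration, so the limit seen for compound 1 is not confined to one configuration: the fact that compounds 1 and 3 differ only in the configuration as drawn. Against the 3-carboxypyrrolidin-1-yl group, this second configuration gives an at least 1.8-fold higher number from compound 2 to compound 3 (0.26 log units; that floor lies within the scatter). The step between the two configurations cannot be read, as both values are limits: the limit of > 50000 nM in this assay, at which 2 of the 3 values shown sit.

The compounds shown leave open how far the true values of compound 1 and compound 3 lie beyond that limit, and so whether the configuration matters at all. Also open, on these data alone, is whether a methyl ester or an amide in place of the carboxylic acid would change the number in either group.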